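Cyclobutyl in place of ethyl on a low-numbered compound

The source may report more compounds than this note shows. Statements on the series, on what has been measured and on what is new or still open speak of the compounds shown alone.

Going by the values given here, in a functional assay (aorta) with Oryctolagus cuniculus as the target (on this read-out higher numbers stand for weaker binding and lower numbers for tighter binding), compound 2 `CCc1nc2c(C)ccnc2n1Cc1ccc(-c2ccccc2C(=O)O)cc1` gives 1.26 nM and holds the lower of the two numbers known so far, while compound 1 `CCCCc1nc2c(C)cccc2n1Cc1cc(Cl)c(O)c(Cl)c1` gives 20 nM and sits beyond the usual scatter from it. Compound 3 `Cc1ccnc2c1nc(C1CCC1)n2Cc1ccc(-c2ccccc2C(=O)O)cc1` has not yet been measured and carries cyclobutyl in place of ethyl on an aromatic carbon on the core of compound 2. Among the compounds with values here, no measured step covers this change, so in this assay only a modest move toward a higher number is expected, with a 2.4-fold higher number from compound 2 to compound 3 (0.38 log units; beyond the scatter) as the estimated step. For compound 3 the estimate is 3 nM with an expected range from 0.8 nM to 12 nM in this read-out.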

Compound 3, dissociation constant: 5.01 nM
Estimate against measurement, compound 3: 1.7-fold (0.22 log units) below; the range from low to high includes it.
By their numbers in this assay, from the lowest: compound 2; then compound 3; then compound 1.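

Cyclobutyl in place of ethyl, on the aromatic carbon between two ring nitrogen atoms, brings a 4.0-fold higher number from compound 2 to compound 3 (0.60 log units; beyond the scatter) in this assay, the only measured step at this position. The position thus takes a four-membered non-aromatic ring of carbon with a modest rise in the number, though one beyond the usual scatter. Nothing available explains this rise.

On these data alone, whether the rise follows from the ring itself or from the added carbon stays open, and a straight butyl chain or a cyclopropyl ring at this place would help separate the two. How an amine would read here is also unknown.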